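Deacetylated and acetylated amino-sugar amides: ear inhibition notes

The source may hold more compounds than are shown below. What is called first, only, known or untested is meant among the compounds shown, and "the series" means these compounds.

Measured compounds:
compound 1, `CC(=O)OC[C@H]1O[C@H](OC(C)=O)[C@H](NC(=O)[C@H](C)NCCC2OCC(C)(C)CO2)[C@@H](OC(C)=O)[C@@H]1OC(C)=O`, gives 84.2% in a functional assay on the whole organism (Ear, strain ICR) for inhibition, with Mus musculus as the target, with stated times of 30 min and 2 h, at a dose of 10 umol/kg by the oral route; a higher number here means more inhibition at the dose given (going by the name of the read-out), a lower number less inhibition
compound 2, `CC(=O)OC[C@H]1O[C@H](OC(C)=O)[C@H](NC(=O)[C@H](CC(C)C)NCCC2OCC(C)(C)CO2)[C@@H](OC(C)=O)[C@@H]1OC(C)=O`, gives 86.6% in this assay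
compound 3, `C[C@H](NCCC1OCC(C)(C)CO1)C(=O)N[C@H]1C(O)O[C@H](CO)[C@@H](O)[C@@H]1O`, gives 86.8% in this assay

Compound 1 and compound 2 share the fully acetylated core and differ only at one place: isopropyl in place of hydrogen on a saturated chain carbon, two bonds along the chain from an amine nitrogen and a carbonyl carbon. The step this change made is a number 2.4 percentage points higher from compound 1 to compound 2 (within the scatter).

Compound 3 carries the free sugar in place of the acetylated one; the difference between the two cores is not broken down here. Its number sits close to those of compound 1 and compound 2, and none of the three can be set apart from the others.

Compound 4, `CC(C)C[C@H](NCCC1OCC(C)(C)CO1)C(=O)N[C@H]1C(O)O[C@H](CO)[C@@H](O)[C@@H]1O`, is not yet measured. It differs from compound 3 in exactly the way compound 2 differs from compound 1: isopropyl in place of hydrogen on a saturated chain carbon, two bonds along the chain from an amine nitrogen and a carbonyl carbon. The place is the same word for word, so this is the same change on the other core. Because the earlier step of a number 2.4 percentage points higher from compound 1 to compound 2 (within the scatter) stayed small, the step from compound 3 to compound 4 is expected to be a number 1.2 percentage points higher from compound 3 to compound 4 (within the scatter). On that basis compound 4 is estimated at 88%, with a range from 78% to 96%, given that compound 3 already gives 86.8% and the read-out cannot rise far above it.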

Compound 4, a percentage reported as inhibition, in the whole organism at one dose (the size of the read-out at that dose, not a potency): 81.8%
Beside the measured number, compound 4's estimate is 6.2 percentage points above it; the measured number falls inside the stated range.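

Within the data shown here, on the free-sugar core, isopropyl in place of hydrogen gives a number 5 percentage points lower from compound 3 to compound 4 (within the scatter) in this assay, and that step cannot be told apart from the one the same change gave on the acetylated core: the same change on two cores in this assay, a number 2.4 percentage points higher (within the scatter) from compound 1 to compound 2 and a number 5 percentage points lower (within the scatter) from compound 3 to compound 4, 7.4 percentage points apart, within the scatter of two such steps. This gives no sign that the core alters what the change does in this series. Among these compounds, with only one pair per core and each step inside the scatter, it does not show that the change carries over unaltered, or that it has a real effect on either core.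

Left open is whether a different group on the same saturated chain carbon, such as a longer chain, an amine or a carboxylic acid, would move the number beyond the scatter on either core. Also open, as far as these compounds go, is how the two cores would compare at other doses, as the read-out here gives the size of the effect at one dose and not a potency.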